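Removing One Chloro Group on Two Related Cores

The compounds below may be only part of what the source reports. "The series", "measured", "known", "first", "only" and "open" are said of these compounds alone.

Compound 1, `ClCc1ccccc1Cn1cnc2c(Cl)nc(Cl)nc21`: 380 nM
Compound 2, `ClCc1ccccc1Cn1cnc2c(Cl)ncnc21`: 14100 nM
Compound 3, `ClCc1ccc(Cn2cnc3nc(Cl)nc(Cl)c32)cc1`: 1650 nM

These three compounds were tested in a functional assay on RPMI-8226 cells (Homo sapiens) for cytotoxicity, read by sulforhodamine B assay, with a stated time of 48 h; on this read-out higher numbers stand for weaker inhibition of growth and lower numbers for stronger inhibition of growth. Compound 1 gives the lowest number of the three, compound 2 the highest, and compound 3 stands between them.

Compound 1 and compound 2 differ in one place: hydrogen in place of chloro on an aromatic carbon. This single change produces a 37-fold higher number from compound 1 to compound 2 (1.57 log units; beyond the scatter). In plain terms, taking away that chloro group leaves a compound that inhibits the growth of the cells far more weakly.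

Compound 3 carries the same pair of chloro groups as compound 1 but on a differently arranged core; the difference between the two cores is not broken down here. Compound 4, `ClCc1ccc(Cn2cnc3ncnc(Cl)c32)cc1`, has not yet been measured. It is related to compound 3 exactly as compound 2 is related to compound 1: hydrogen in place of chloro on an aromatic carbon. The place description is the same word for word in both pairs, so this is the same change made on a second core.

Among the compounds with values here, the one earlier example of this change, a 37-fold higher number from compound 1 to compound 2 (1.57 log units; beyond the scatter), was large. Since compound 3 already sits at a weaker starting point than compound 1, compound 4 is expected to land well above it, with an estimated step of a 30-fold higher number from compound 3 to compound 4 (1.48 log units; beyond the scatter). Within the data shown here, compound 4 is therefore estimated at 50000 nM in this assay, with a likely range from 15000 nM to 200000 nM; the single prior example leaves this expectation uncertain.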

Compound 4, concentration for 50% growth inhibition: 1280 nM
The estimate for compound 4 lay 39-fold (1.59 log units) above the measured number; measured number below the stated range.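

In this assay, removing the chloro group on the second core gives a 1.3-fold lower number from compound 3 to compound 4 (0.11 log units; within the scatter), a step too small to separate from the ordinary scatter of repeated measurements, so this pair shows no real difference in growth inhibition. The large loss seen on the first core therefore does not carry over to the second, and a single change can have very different consequences depending on the core that carries it: the same change on two cores in this assay, a 37-fold higher number (1.57 log units; beyond the scatter) from compound 1 to compound 2 and a 1.3-fold lower number (0.11 log units; within the scatter) from compound 3 to compound 4, 48-fold (1.68 log units) apart, beyond the scatter of two such steps. Within the data shown here, this does not show why the two pairs behave differently or which pair is the more typical, since each core offers only one example and compound 1 and compound 3 differ from each other in more than one place.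

The compounds shown leave open what an amine or a methoxy group would do on that aromatic carbon between two ring nitrogen atoms, and whether either core would then respond as it does to hydrogen. All of the compounds also carry a chloromethyl group, so what a plain methyl group in its place would do to growth inhibition on either core remains an open question as well.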